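Shortening the hydroxyalkyl chain on the enaminone amine

A few compounds are considered here, and "the series" means these few. Any claim that something is new, unique, unknown or untested is made for them only; others in the source may bear on it.

Compound 1, `COc1cc(/C=C/C(=O)/C=C(/C=C/c2ccc(O)c(OC)c2)NCCO)ccc1O`, gives 103% in a functional assay on Caco-2 cells (Homo sapiens) for activation, read by fluorescence, tested at 1 uM; a lower number here means a stronger effect, a higher number a weaker effect of the compound at the concentration tested. Compound 2, `COCCCN1C(/C=C/c2ccc(O)cc2)=CC(=O)CC1c1ccc(O)cc1`, gives 99% in this assay. Compound 3, `O=C(/C=C(/C=C/c1ccc(O)cc1)NCCCO)/C=C/c1ccc(O)cc1`, gives 94.1% in this assay.

Among these three numbers compound 3 has the lowest one. Its nearest neighbour is compound 2, whose number lies within the scatter of it, and the furthest is compound 1, whose number also lies within the scatter. The three values therefore cannot be told apart, and none of the compounds can be called the stronger or the weaker in this assay on this evidence.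

Compound 4 is `O=C(/C=C(/C=C/c1ccc(O)cc1)NCCO)/C=C/c1ccc(O)cc1`. It differs from compound 3 in one place: hydroxy in place of hydroxymethyl on a saturated chain carbon, two bonds along the chain from an amine nitrogen.

For the measured compounds named here, no pair of measured compounds that differ in a single place is available, so no measured step can guide the expectation. What the three numbers do show is that compounds of this kind, with different substituents on the amine nitrogen, all land close to one another. On that basis the step from compound 3 to compound 4 in this assay is expected to be a number 2.9 percentage points higher from compound 3 to compound 4 (within the scatter), that is, nothing beyond the scatter in either direction. Compound 4 is estimated to give 97%, with a range from 85% to 109%.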

Compound 4, a percentage reported as activity, at one concentration (the size of the read-out at that concentration, not a potency): 98.1%
Compound 4: middle estimate off by 1.1 percentage points, on the low side, and the stated range covers the measured number.
By their numbers in this assay, from the lowest: compounds 3, 4, 2 and 1 (each within the scatter of the next).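

In this assay, for the compounds shown here, the pair gives the first step that can be read at a single place: exchanging 3-hydroxypropyl for 2-hydroxyethyl on the amine nitrogen gives a number 4 percentage points higher from compound 3 to compound 4 (within the scatter). This step shows that, at the one concentration tested, the assay does not separate these two hydroxyalkyl chains at this position, even though the terminal hydroxy group stays on the chain and only the chain length differs. No measurement at hand bears on why the two chains cannot be told apart.

The compounds shown leave open whether a longer chain such as 4-hydroxybutyl, or a different group at the end of the chain such as an amine, a methoxy group or a carboxylic acid, would move the number beyond the scatter. They also leave open whether the same exchange of chains would read the same way on a core carrying the methoxy groups of compound 1, and whether any group at this position gives a number that can be told apart from those of compound 3 and compound 4.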